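The compounds below may be only part of what the source reports. "The series", "measured", "known", "first", "only" and "open" are said of these compounds alone.

Measured so far in an ADME assay on MT4 cells (Homo sapiens) for cytotoxicity, read by MTT assay, with a stated time of 4 days; on this read-out higher numbers stand for lower toxicity in this test and lower numbers for higher toxicity in this test:
- compound 1, `Cc1cc(-c2ccccc2C(F)(F)F)cc(C)c1Nc1ccnc(Nc2ccc(C#N)cc2)n1`: 4210 nM
- compound 2, `Cc1ccc(-c2cc(C)c(Nc3ccnc(Nc4ccc(C#N)cc4)n3)c(C)c2)cc1`: 5570 nM
- compound 3, `COc1ccc(-c2cc(C)c(Nc3ccnc(Nc4ccc(C#N)cc4)n3)c(C)c2)cc1`: 2890 nM

The three numbers sit close together. Compound 2 gives the highest number of the three, yet its neighbours lie within the scatter: the step of a 1.3-fold higher number from compound 1 to compound 2 (0.12 log units; within the scatter) and the step of a 1.9-fold lower number from compound 2 to compound 3 (0.28 log units; within the scatter) are both small, as is the step of a 1.5-fold lower number from compound 1 to compound 3 (0.16 log units; within the scatter). Swapping the substituted phenyl group on the shared core of compound 2 has so far moved the cytotoxicity read-out by no more than the usual noise of this assay.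

Compound 4, `Cc1cc(-c2c(C)cccc2C)cc(C)c1Nc1ccnc(Nc2ccc(C#N)cc2)n1`, is not yet measured. It differs from compound 2 in one place: 2,6-dimethylphenyl in place of 4-methylphenyl on an aromatic carbon. The measured steps that bear on it are those in which the same aryl position carries a different substituted phenyl, and none of them moved the read-out beyond the scatter. Nothing seen so far suggests that 2,6-dimethylphenyl would behave differently, so no step beyond the scatter is expected, giving an estimated step of a 1.2-fold lower number from compound 2 to compound 4 (0.09 log units; within the scatter).

Compound 4 is therefore estimated at 4500 nM in this assay, with an expected range from 2000 nM to 10000 nM.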

Compound 4, half-maximal cytotoxic concentration: 2590 nM
Estimate against measurement, compound 4: 1.7-fold (0.24 log units) above; measured number inside the range.
By their numbers in this assay, from the lowest: compounds 4, 3, 1 and 2 (each within the scatter of the next, the first and the last beyond it).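

In this assay, this place on the shared core gives its first step beyond the scatter: 2,6-dimethylphenyl in place of 4-methylphenyl brings a 2.2-fold lower number from compound 2 to compound 4 (0.33 log units; beyond the scatter) and is a modest change. The same group in place of 4-methoxyphenyl brings a 1.1-fold lower number from compound 3 to compound 4 (0.05 log units; within the scatter) and in place of 2-(trifluoromethyl)phenyl brings a 1.6-fold lower number from compound 1 to compound 4 (0.21 log units; within the scatter) and so, among the four aryl groups, compound 4 separates from compound 2 alone, while every other pair stays within the scatter and the band of numbers remains narrow. For the compounds shown here, nothing available accounts for the one step beyond the scatter.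

Every compound shown carries a substituted phenyl group at this place, with only methyl, methoxy and trifluoromethyl as substituents, so whether a phenyl bearing an amine or a carboxylic acid would leave the number in this band stays open. Also open, on these data alone, is whether the step seen for 2,6-dimethylphenyl needs both of its methyl groups, or whether a single methyl group on the ring would give a number closer to that of compound 2 in this assay on the same core.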